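The compounds below may be only part of what the source reports. "The series", "measured", "known", "first", "only" and "open" are said of these compounds alone.

Measured in a physicochemical assay for lipophilicity, at pH 7.4; on this read-out higher numbers stand for higher lipophilicity and lower numbers for lower lipophilicity:
Compound 1 `CNC(=O)c1cc(C(=O)N[C@H]2[C@@H]3C[C@@H](O)C[C@@H]32)cc2c1OC[C@H]2c1ccccc1`: 2.9
Compound 2 `CNC(=O)c1cc(C(=O)NC2CC2)cc2c1OC[C@H]2c1cccc(F)c1`: 3.7

Of these two, compound 2 stands highest at 3.7, while compound 1 lies lower at 2.9, a gap beyond the usual scatter. Compound 3 `CNC(=O)c1cc(C(=O)NC2CC2)cc2c1OC[C@H]2c1ccccc1` differs from compound 2 by hydrogen in place of fluoro on an aromatic carbon, with hydrogen in place of fluoro on an aromatic carbon, so that 3-fluorophenyl becomes phenyl. For the measured compounds named here, no measured pair differs in one place, so the expectation rests on this change alone: a small downward step in this assay, probably within the scatter. The expected change is a number 0.20 log units lower from compound 2 to compound 3 (within the scatter). Compound 3 is estimated at 3.5, with an expected range from 3.2 to 3.8.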

Compound 3, distribution coefficient: 3.6
Compound 3: the middle estimate sits 0.10 log units below what was measured; the measured number falls inside the stated range.
By their numbers in this assay, from the lowest: compound 1; then compounds 3 and 2 (each within the scatter of the next).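

In this assay, the change from 3-fluorophenyl to phenyl gives a number 0.10 log units lower from compound 2 to compound 3 (within the scatter), so at this place on the aromatic ring the two groups cannot be told apart. With phenyl on both, the group of 3 heavy atoms in place of the group of 7 heavy atoms on the amide-type nitrogen gives a number 0.70 log units higher from compound 1 to compound 3 (beyond the scatter), a comparison that differs in one place only. Nothing measured here explains either step. Still open, going by these compounds, is how an amine or a nitrile on that aromatic carbon would read in this assay, and which part of the larger group on the amide-type nitrogen accounts for its step.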